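The source may report more compounds than this note shows. Statements on the series, on what has been measured and on what is new or still open speak of the compounds shown alone.

Compound 1 `COc1ccc(-n2nncc2CN2C(=O)C3(C(C#N)=C(N)Oc4c3c3nc5ccccc5nc3c3ccccc43)c3ccccc32)cc1`: in a functional assay on A549 cells (Homo sapiens) for antiproliferative activity, read by MTT assay, with a stated time of 48 h (a lower number here means a stronger inhibitor, a higher number a weaker inhibitor), compound 1 gives > 50000 nM, which is a limit of the assay and not a number.
Compound 2 `Cc1ccc(Cl)cc1-n1nncc1CN1C(=O)C2(C(C#N)=C(N)Oc3c2c2nc4ccccc4nc2c2ccccc32)c2ccccc21`: in this assay compound 2 gives > 50000 nM, again a limit and not a number.
Compound 3 `N#CC1=C(N)Oc2c(N)cc3nc4ccccc4nc3c2C12C(=O)N(Cc1cnnn1-c1cccc(C(F)(F)F)c1)c1ccccc12`: in this assay compound 3 gives 5400 nM.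

Among the measured compounds shown here, compound 3 therefore stands alone as the only compound of the three with a number; the other two sit at the limit of > 50000 nM in this assay, at which 2 of the 3 values shown sit, so nothing can be said about their order relative to compound 3 beyond the fact that compound 3 is the one resolved value.

Compound 4 `Cc1ccc(C)c(-n2nncc2CN2C(=O)C3(C(C#N)=C(N)Oc4c(N)cc5nc6ccccc6nc5c43)c3ccccc32)c1` differs from compound 3 in one place: 2,5-dimethylphenyl in place of 3-(trifluoromethyl)phenyl on an aromatic nitrogen.

For the measured compounds named here, only one step between measured compounds exists, a step that the two limits leave unreadable from compound 1 to compound 2, and it also swaps the group on an aromatic nitrogen, but its size cannot be read because both ends are at the limit of > 50000 nM in this assay, at which 2 of the 3 values shown sit. Going by the values given here, no measured step therefore tells how large a change in this assay this kind of swap produces, in either direction. The expectation is accordingly built on compound 3 alone, with no shift beyond the scatter assumed.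

Compound 4 is expected to give about 6000 nM, within 1500 nM to 30000 nM, in this assay. The step that this estimate means from compound 3 to compound 4 is expected to be a 1.1-fold higher number from compound 3 to compound 4 (0.05 log units; within the scatter).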

Compound 4, half-maximal inhibitory concentration: > 50000 nM
Compound 4: a limit, no number; the forecaster's own chance of this, stated with the estimate: 25%; at least 8.3-fold (0.92 log units) between middle value and limit.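

In this assay, putting 2,5-dimethylphenyl in place of 3-(trifluoromethyl)phenyl on the aromatic nitrogen gives an at least 9.2-fold higher number from compound 3 to compound 4 (0.96 log units; beyond the scatter), so the group at this position can shift the read-out beyond the scatter, which the unreadable step between the two earlier limits could not show. The two groups have the same kind of carbon-only aromatic ring, and neither has a hydrogen-bond donor, a hydrogen-bond acceptor or a net charge, so those counts do not separate them; they differ in the substituents on that ring, three fluorine atoms on one carbon in one case and two separate methyl groups in the other. Compound 4 gives a limit and not a number, so the step has a minimum size only: the limit of > 50000 nM in this assay, at which 3 of the 4 values shown sit.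

As far as these compounds go, it remains open whether the loss follows from removing the trifluoromethyl group or from adding a methyl group at the 2 or the 5 position, since this single step changes all of these together. A 3-methylphenyl or 3-chlorophenyl group at this nitrogen, or an amine or a carboxylic acid on the phenyl ring, would help to separate these possibilities.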